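Swapping a Methyl for Dimethylamino on a Receptor Agonist

The source may hold more compounds than are shown below. What is called first, only, known or untested is meant among the compounds shown, and "the series" means these compounds.

Of the compounds shown here, three have been tested so far in an assay on HEK293 cells for agonist activity at Toll-like receptor 8 (Homo sapiens), read by reporter gene assay; a higher number here means that more compound is needed for the effect, a lower number that less compound is needed. Compound 1, `CCCCC1(O)C(N)=Nc2ccccc21`, gives "not active" (no number reported), so no number is available for it. Compound 2, `CCCCCn1c(N)nc2ccncc21`, likewise gives "not active" (no number reported) in this assay. Compound 3, `CCCCCn1c(N)nc2c(C)cccc21`, is the one entry with a numerical result: in this assay compound 3 gives 1130 nM. Within the data shown here, compound 3 therefore stands alone with a number, while the other two were reported only in words, and no step between two numbered compounds can be drawn from these data.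

The next compound, compound 4, is `CCCCCn1c(N)nc2c(N(C)C)cccc21`. It differs from compound 3 in one place: dimethylamino in place of methyl on an aromatic carbon. Among the measured compounds shown here, since no measured step of this kind is available here, nothing in the data shows how large an effect such a swap has in this assay. Compound 3 is the only anchor, and its value of 1130 nM is taken as the starting point. The step from compound 3 to compound 4 is expected to be small, a 1.4-fold lower number from compound 3 to compound 4 (0.15 log units; within the scatter), plausibly within the usual scatter, with a slight lean toward less compound being needed. Compound 4 is accordingly estimated at 800 nM in this assay, with a range from 250 nM to 3000 nM.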

Compound 4, half-maximal effective concentration: 7120 nM
Estimate against measurement, compound 4: 8.9-fold (0.95 log units) below; the whole stated range lies below it.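

Replacing methyl with dimethylamino on this aromatic carbon, ortho to a fused ring, gives a 6.3-fold higher number from compound 3 to compound 4 (0.80 log units; beyond the scatter) in this assay, so more compound is needed for the effect and the position is not indifferent to what sits on it. Even so, compound 4 still gives a measurable number, 7120 nM, so this swap weakens the effect without abolishing it. Dimethylamino brings 3 heavy atoms where methyl has 1, and 1 hydrogen-bond acceptor where methyl has 0, but nothing available shows which of these differences matters or why the number rises.

Going by these compounds, whether a plain amine, a methoxy group or a chlorine atom on this same carbon would shift the number in the same direction, and by a similar amount, remains open. Among these compounds, a single step also cannot show whether dimethylamino would have the same result on other aromatic carbons of the shared core, or alongside a longer chain in place of the one carried by compound 3 and compound 4.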